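A Methyl Added to Compound 2

The compounds below may be only part of what the source reports. "The series", "measured", "known", "first", "only" and "open" are said of these compounds alone.

In a physicochemical assay for solubility, in phosphate buffer, measured as kinetic solubility, with a stated time of 24 h, at pH 6.5 (a lower number here means a less soluble compound, a higher number a more soluble compound), compound 1 `CC(C)Oc1cc(Oc2ccc(S(C)(=O)=O)cc2)cc(-c2cncc(=O)[nH]2)c1` reads 118000 nM and compound 2 `CC(C)Oc1cc(Oc2ccc(S(C)(=O)=O)cc2)cc(-c2nccc(=O)[nH]2)c1` reads 25000 nM (the lower of the two numbers). Compound 3 `Cc1cnc(-c2cc(Oc3ccc(S(C)(=O)=O)cc3)cc(OC(C)C)c2)[nH]c1=O` departs from compound 2 by a single change (methyl in place of hydrogen on an aromatic carbon) with methyl in place of hydrogen on an aromatic carbon. Within the data shown here, the only measured step is a 4.7-fold lower number from compound 1 to compound 2 (0.67 log units; beyond the scatter) and it swaps one six-membered aromatic ring for another without adding a methyl, so it serves only as a rough yardstick for the size of a small change. Among the measured compounds shown here, no measured pair tests a methyl directly. In this assay the expected change is a 2.1-fold lower number from compound 2 to compound 3 (0.32 log units; beyond the scatter) (a modest fall, no larger than the measured step). Compound 3 is estimated at 12000 nM with an expected range from 4000 nM to 35000 nM for a single measurement.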

Compound 3, solubility: 1900 nM
Compound 3: middle estimate off by 6.3-fold (0.80 log units), on the high side, outside the stated range (below it).
By their numbers in this assay, from the lowest: compound 3; then compound 2; then compound 1.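

In this assay, a methyl in place of hydrogen on an aromatic carbon, para to a large group and two atoms from the ring nitrogen, now has a direct reading: a 13-fold lower number from compound 2 to compound 3 (1.12 log units; beyond the scatter). This addition of one carbon is classed as large, whereas the swap of one six-membered aromatic ring for another, a 4.7-fold lower number from compound 1 to compound 2 (0.67 log units; beyond the scatter), is classed as modest, so a ring swap no longer marks the size a small change can reach in this series. Taken together, the two changes give a 62-fold lower number from compound 1 to compound 3 (1.79 log units; beyond the scatter), which leaves compound 3 with the lowest number of the three.

Nothing measured here bears on why this methyl has so large an effect. As far as these compounds go, whether an ethyl group or a methoxy group at this position would give a step of similar size remains open.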